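Thiophene variation at the carbonyl of a quinoline chalcone

This account rests on a few compounds, and the source may have more. Where it says the series, first, only, none or still open, it means among the compounds named here.

Compound 3 `COc1ccc(-c2cc3ccccc3nc2/C=C/C(=O)c2ccsc2)cc1` gives 1060 nM in a functional assay on MDA-MB-231 cells (Homo sapiens) for antiproliferative activity, read by XTT assay, with a stated time of 72 h (on this read-out higher numbers stand for weaker inhibition and lower numbers for stronger inhibition), the lowest of the two plain numbers shown. Compound 1 `COc1ccc(C(=O)/C=C/c2nc3ccccc3cc2-c2ccc(OC)cc2)cc1` gives 7540 nM in this assay. Compound 2 `COc1ccc(-c2cc3ccccc3nc2/C=C/C(=O)c2ccc(Br)s2)cc1` reaches only a limit of this assay, < 100 nM, and is therefore not a number. Compound 4 `COc1ccc(-c2cc3ccccc3nc2/C=C/C(=O)c2sccc2N)cc1` differs from compound 3 by 3-aminothiophen-2-yl in place of thiophen-3-yl on a carbonyl carbon. The measured steps touching this carbonyl group were sizeable: a 7.1-fold lower number from compound 1 to compound 3 (0.85 log units; beyond the scatter) and an at least 10-fold higher number from compound 2 to compound 3 (1.02 log units; beyond the scatter). The second shows that another substituted thiophen-2-yl on this carbonyl reached the limit (the limit of < 100 nM in this assay, at which 1 of the 3 values shown sits), so a lower number than compound 3 is plausible, though the amino group is a different substituent. For compound 4 a modest step is expected, a 2.4-fold lower number from compound 3 to compound 4 (0.37 log units; beyond the scatter). The estimate for compound 4 is 450 nM, with a range from 120 nM to 1700 nM.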

Compound 4, half-maximal inhibitory concentration: > 10000 nM
Compound 4: no number, only a limit (the forecaster's own chance of this, stated with the estimate: 15%); middle value at least 22-fold (1.34 log units) away from the limit.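

In this assay compound 4 stands at a limit, > 10000 nM, and not at a number. A thiophene on this carbonyl therefore does not guarantee activity, and substituted thiophen-2-yl groups can sit far apart: an at least 9.4-fold higher number from compound 3 to compound 4 (0.97 log units; beyond the scatter), and an at least 100-fold higher number from compound 2 to compound 4 (2.00 log units; beyond the scatter). The remaining step, an at least 1.3-fold higher number from compound 1 to compound 4 (0.12 log units; that floor lies within the scatter), cannot be read as a difference.

The compounds shown do not separate the amine from the change of thiophen-3-yl to a thiophen-2-yl attachment. An unsubstituted thiophen-2-yl or a 3-methylthiophen-2-yl on this carbonyl would help to tell these apart.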